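Swapping the anilino ring of a sulfonyl-bearing core

The source may report more compounds than this note shows. Statements on the series, on what has been measured and on what is new or still open speak of the compounds shown alone.

Measured so far:
compound 1 `COc1cc(Nc2nc3ccccc3nc2S(=O)(=O)c2ccccc2)cc(OC)c1` — 50 nM
compound 2 `COc1ccc(Nc2nc3ccccc3nc2S(=O)(=O)c2ccc(C)cc2)cc1` — 2790 nM

Two compounds share a core carrying a sulfonyl group and an aromatic amine. In a functional assay on HL-60 cells (Homo sapiens) for cytotoxicity, read by MTT assay, with a stated time of 72 h (on this read-out lower numbers stand for stronger inhibition and higher numbers for weaker inhibition), compound 1 gives 50 nM, while compound 2 gives 2790 nM, the weaker of the two numbers and separated from compound 1 by a gap well beyond the usual scatter. The two differ in two places at once, so the gap cannot be assigned to either change alone.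

Compound 3 `COc1cc(Nc2nc3ccccc3nc2S(=O)(=O)c2ccc(C)cc2)cc(OC)c1` is not yet measured. It differs from compound 2 in one place: 3,5-dimethoxyphenyl in place of 4-methoxyphenyl on a nitrogen on an aromatic ring. Compound 3 keeps the sulfonyl substituent of compound 2 but carries the amine-side ring of compound 1. Because compound 1 with that ring gives 50 nM, a move toward lower numbers is expected, though of uncertain size, since the sulfonyl side still differs from compound 1. The expected step is an 11-fold lower number from compound 2 to compound 3 (1.05 log units; beyond the scatter). For compound 3 the estimate in this assay is 250 nM, with a range from 50 nM to 1200 nM.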

Compound 3, half-maximal inhibitory concentration: 20 nM
The estimate for compound 3 lay 13-fold (1.10 log units) above the measured number; measured number outside the range, below it.
By their numbers in this assay, from the lowest: compound 3; then compound 1; then compound 2.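

In this assay, the change from 4-methoxyphenyl to 3,5-dimethoxyphenyl on the nitrogen, made with everything else held fixed, gives a 140-fold lower number from compound 2 to compound 3 (2.14 log units; beyond the scatter), so this ring's effect can now be read on its own, which the earlier pair did not allow. On the sulfonyl side, methyl in place of hydrogen on an aromatic carbon gives a 2.5-fold lower number from compound 1 to compound 3 (0.40 log units; beyond the scatter), a modest step that is still beyond the scatter, so here the amine-side ring change is the much larger of the two. Nothing measured here bears on the reason for either step. The compounds shown leave open whether the large step needs both methoxy groups, and whether ethoxy or chlorine could take their place. As far as these compounds go, whether an ethyl group or a chlorine could replace the methyl also remains open.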